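Fluoro for Hydrogen on the Triazole Phenyl Ring

This account rests on a few compounds, and the source may have more. Where it says the series, first, only, none or still open, it means among the compounds named here.

Measured compounds:
Compound 1, `Cc1cccc(-n2cc(-c3ccccc3NS(=O)(=O)c3c[nH]c(=O)[nH]c3=O)nn2)c1`: 1870 nM
Compound 2, `O=c1[nH]cc(S(=O)(=O)Nc2cccc(-c3cn(-c4ccccc4)nn3)c2)c(=O)[nH]1`: 12700 nM

Both compounds were tested in a functional assay on A549 cells (Homo sapiens) for antiproliferative activity, read by MTT assay, with a stated time of 24 h; on this read-out lower numbers stand for stronger inhibition and higher numbers for weaker inhibition. Of the two numbers, compound 2 has the higher one, and its nearest neighbour, compound 1, lies well beyond the usual scatter, so compound 2 is the weaker inhibitor of the pair. The two compounds differ in more than one place, so their gap cannot be tied to a single change.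

Compound 3, `O=c1[nH]cc(S(=O)(=O)Nc2cccc(-c3cn(-c4ccc(F)cc4)nn3)c2)c(=O)[nH]1`, is not yet measured. It differs from compound 2 in one place: fluoro in place of hydrogen on an aromatic carbon. For the measured compounds named here, no step between measured compounds matches this change, so the expectation rests on its small size alone. In this assay a step of this kind is expected to stay within the scatter, with no clear direction, as a 1.2-fold lower number from compound 2 to compound 3 (0.06 log units; within the scatter). Compound 3 is therefore estimated at 11000 nM, in a range from 4000 nM to 30000 nM.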

Compound 3, half-maximal inhibitory concentration: > 20000 nM
Compound 3: only a limit was reported; the forecaster's own chance of this, stated with the estimate: 5%; middle value at least 1.8-fold (0.25 log units) away from the limit.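

Compound 3 gives > 20000 nM in this assay, and this is a limit of the assay, not a number. Going from phenyl to 4-fluorophenyl, with fluoro on an aromatic carbon para to a large group, gives an at least 1.5-fold higher number from compound 2 to compound 3 (0.19 log units; that floor lies within the scatter), so this first change on the triazole phenyl ring brings no gain in inhibition, but it cannot be called a loss beyond the scatter. The step has only a floor and no true size, and that floor comes from a single reported limit: the limit of > 20000 nM in this assay, at which 1 of the 3 values shown sits.

Still open, going by these compounds, is how other groups at this place, such as chloro, methoxy or an amine, would compare with hydrogen and fluoro. Also open, on these data alone, is which of the several differences between compound 1 and compound 2 matters most.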